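Nitro for Chloro on an Aryl Piperazine Ether

The source may report more compounds than this note shows. Statements on the series, on what has been measured and on what is new or still open speak of the compounds shown alone.

Measured compounds:
Compound 1, `Clc1ccc(N2CCN(CCCCOc3ccc4c(c3)CCC4)CC2)cc1`: 33%
Compound 2, `COc1ccccc1N1CCN(CCCOc2ccc3c(c2)CCC3)CC1`: 19%

Of the compounds shown here, two have been tested in a functional assay on the whole organism for inhibition, with Mus musculus as the target, at a dose of 25 mg/kg by the oral route; on this read-out lower numbers stand for less inhibition and higher numbers for more inhibition at the one dose given (going by the name of the read-out). Among the measured compounds shown here, compound 1 stands highest of the two; its only neighbour, compound 2, gives a lower number, and the gap between them lies beyond the usual scatter of this kind of measurement, so compound 1 shows the stronger inhibition of the pair at the dose given.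

Compound 3, `O=[N+]([O-])c1ccc(N2CCN(CCCCOc3ccc4c(c3)CCC4)CC2)cc1`, is the compound not yet measured. It differs from compound 1 only by nitro in place of chloro on an aromatic carbon. For the measured compounds named here, no pair of measured compounds shows this same change, so the two numbers so far give no measured step to lean on. Without such a reference, the most cautious expectation is a step that stays within the scatter, with no clear direction; the expected step is a number 2 percentage points higher from compound 1 to compound 3 (within the scatter). Compound 3 is therefore estimated to give 35%, within a range from 12% to 58%.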

Compound 3, a percentage reported as inhibition, in the whole organism at one dose (the size of the read-out at that dose, not a potency): 22%
For compound 3 the middle estimate is 13 percentage points above the measured one; the measured number falls inside the stated range.
By their numbers in this assay, from the lowest: compounds 2 and 3 (each within the scatter of the next); then compound 1.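

In this assay, among the compounds shown here, nitro in place of chloro gives a number 11 percentage points lower from compound 1 to compound 3 (beyond the scatter), the first measured step at this position. It shows that the aromatic carbon para to a large group is sensitive to what it carries: within this pair, 4-chlorophenyl gives the higher number at the one dose given, and 4-nitrophenyl the lower. No measurement available here explains why the number falls.

A single step cannot show how other groups would fare at this position, such as an amine, a nitrile or a carboxylic acid. For the compounds shown here, it also leaves open whether the same exchange would produce a similar step with a longer chain in place of the one shared by compound 1 and compound 3.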